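This account rests on a few compounds, and the source may have more. Where it says the series, first, only, none or still open, it means among the compounds named here.

Three compounds have been measured in a functional assay on NPC-TW01 cells (Homo sapiens) for antiproliferative activity, read by MTT assay, with a stated time of 72 h; on this read-out lower numbers stand for stronger inhibition of growth and higher numbers for weaker inhibition of growth:
compound 1 `COc1ccc(NC(=O)COc2ccc3oc(-c4ccccc4)cc(=O)c3c2)cc1`, 710 nM;
compound 2 `O=C(COc1ccc2oc(-c3ccccc3)cc(=O)c2c1)Nc1ccc(-c2ccccc2)cc1`, 640 nM;
compound 3 `COc1ccc(NC(=O)COc2ccc3c(=O)cc(-c4ccccc4)oc3c2)cc1`, 5970 nM.

Compound 1 and compound 2 share one core, and the change between them, (phenyl in place of methoxy on an aromatic carbon), gave a 1.1-fold lower number from compound 1 to compound 2 (0.05 log units; within the scatter). Compound 3 is built from the same atoms as compound 1, joined differently; the difference between the two cores is not broken down here. Its value is the highest of the three, beyond the scatter from either of the others. Compound 4 `O=C(COc1ccc2c(=O)cc(-c3ccccc3)oc2c1)Nc1ccc(-c2ccccc2)cc1` has not been measured. It arises from compound 3 by phenyl in place of methoxy on an aromatic carbon, the same change at the same place as that between compound 1 and compound 2. Compound 4 is expected to move by only a 1.1-fold lower number from compound 3 to compound 4 (0.04 log units; within the scatter), because the same change earlier gave a 1.1-fold lower number from compound 1 to compound 2 (0.05 log units; within the scatter). In this assay compound 4 is therefore estimated at 5500 nM, most likely between 2500 nM and 12000 nM.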

Compound 4, concentration for 50% growth inhibition: 1610 nM
Beside the measured number, compound 4's estimate is 3.4-fold (0.53 log units) above it; the measured number lies below the stated range.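

In this assay putting phenyl in place of methoxy gave a 3.7-fold lower number from compound 3 to compound 4 (0.57 log units; beyond the scatter) and so lowered the number on the core of compound 3, whereas on the core of compound 1 the same change stayed within the scatter. The size of this step therefore did not carry over from one core to the other: the same change on two cores in this assay, a 1.1-fold lower number (0.05 log units; within the scatter) from compound 1 to compound 2 and a 3.7-fold lower number (0.57 log units; beyond the scatter) from compound 3 to compound 4, 3.3-fold (0.52 log units) apart, beyond the scatter of two such steps. Among the compounds shown here, with only two pairs, this shows that the outcome of the change depends on the core, but it does not show why, or what the change would do on a third core.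

Still open, on these data alone, is how other groups at this place, such as an amine or a carboxylic acid, would behave on these two cores.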